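Inverting a Ring Stereocentre: Expected Stability of Compound 3

The source may report more compounds than this note shows. Statements on the series, on what has been measured and on what is new or still open speak of the compounds shown alone.

Compound 1 `O=C(O)[C@H](CO)NC(=O)[C@H]1C[C@H](O)CN1` and compound 2 `O=C(O)[C@H](CO)NC(=O)[C@H]1C[C@@H](O)CN1` share the same atoms and bonds. In an ADME assay on Jejunum (Mus musculus, strain C57BL/6) for metabolic stability, read by HPLC, with a stated time of 12 h (a lower number here means that the compound disappears faster, a higher number that the compound lasts longer), compound 1 gives > 12 h, which is a limit of the assay rather than a number. In this assay compound 2 likewise gives > 12 h, again a limit. The step that the two limits leave unreadable from compound 1 to compound 2 cannot be read because of the limit of > 12 h in this assay, at which 2 of the 2 values shown sit. Compound 3 `O=C(O)[C@H](CO)NC(=O)[C@@H]1C[C@@H](O)CN1` differs from compound 2 by the two compounds have the same atoms and bonds and differ only in configuration as drawn: 1 of 3 stereo elements differ; a stereocentre at a saturated ring carbon is drawn R in compound 2 and S in compound 3. Among the compounds with values here, only that unreadable step bears on this change, so no step beyond the scatter in this assay is expected. The step that the limit leaves unreadable from compound 2 to compound 3 is therefore expected to be essentially none. The estimate for compound 3 is 14 h, expected between 8 h and 30 h.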

Compound 3, half-life: 0.35 h
Estimate against measurement, compound 3: 40-fold (1.60 log units) above, and the stated range ends above it.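

Compound 1 and compound 2 both sit at limits of the assay, and the step between them cannot be read. Inverting one saturated ring carbon, with nothing entering or leaving, now gives an at least 34-fold lower number from compound 2 to compound 3 (1.53 log units; beyond the scatter), the first readable sign that configuration at this position counts in this assay. Changing both ring stereocentres gives an at least 34-fold lower number from compound 1 to compound 3 (1.53 log units; beyond the scatter).

From the compounds shown here alone, whether the other ring stereocentre alone would produce such a step stays open, as does the role of the stereocentre outside the ring. Going by these compounds, it is also open how an amine or a methyl ether in place of the ring hydroxyl would behave on the core of compound 3.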